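The source may hold more compounds than are shown below. What is called first, only, known or untested is meant among the compounds shown, and "the series" means these compounds.

In a functional assay on NCI/ADR-RES cells (Homo sapiens) for cytotoxicity, read by sulforhodamine B assay, with a stated time of 48 h (on this read-out lower numbers stand for stronger inhibition of growth and higher numbers for weaker inhibition of growth), the three measured compounds stand as follows:

compound 1 `CC1=C(C(=O)Nc2ccc(Cl)c(Cl)c2)C(c2cccc(O)c2)NC(=S)N1`: 15800 nM
compound 2 `CC1=C(C(=O)Nc2ccc(F)c(Cl)c2)C(c2cccc(Oc3ccccc3)c2)NC(=O)N1`: 16200 nM
compound 3 `CC1=C(C(=O)Nc2ccc(Cl)c(Cl)c2)C(c2ccccc2Cl)NC(=S)N1`: 15800 nM

Compound 1 is level with compound 3 at the digits shown, and the two together hold the lowest numbers of the three; compound 2 stands a hair higher, but this gap lies within the scatter, so the three values cannot be told apart.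

Compound 4 `CC1=C(C(=O)Nc2ccc(F)c(Cl)c2)C(c2cccc(O)c2)NC(=S)N1` has not yet been measured. It differs from compound 1 in one place: fluoro in place of chloro on an aromatic carbon. Among the measured compounds shown here, no measured step covers this exchange. For the measured compounds named here, the only step recorded, no change at the digits printed from compound 1 to compound 3 (within the scatter), concerns a different position and shows that a sizeable change on the saturated ring carbon left the number where it was. Compound 4 carries the same 3-chloro-4-fluorophenyl amide as compound 2, which gives 16200 nM, again indistinguishable from compound 1 and compound 3. Nothing in these data points to a shift beyond the scatter, so the step from compound 1 to compound 4 is expected to be no change at the digits printed from compound 1 to compound 4 (within the scatter). Compound 4 is therefore estimated at 15800 nM, with a likely range from 6000 nM to 40000 nM.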

Compound 4, concentration for 50% growth inhibition: 17000 nM
Estimate against measurement, compound 4: 1.1-fold (0.03 log units) below; the range from low to high includes it.
By their numbers in this assay, from the lowest: compounds 1, 3, 2 and 4 (each within the scatter of the next).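

In this assay, the exchange of fluoro for chloro on the aromatic carbon para to a large group, which turns the 3,4-dichlorophenyl into a 3-chloro-4-fluorophenyl, reads as a 1.1-fold higher number from compound 1 to compound 4 (0.03 log units; within the scatter). This is the only step shown at this position, and it adds a second place to the saturated ring carbon where a single exchange stays within the scatter, here with the 3-hydroxyphenyl group held constant. No evidence at hand bears on this result.

Chloro and fluoro are both single atoms, so the compounds shown leave open what a methoxy group, an amine or a carboxylic acid at this position would give. Also open, from the compounds shown here alone, is what a change to the chloro group ortho to this position would do.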